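The compounds below may be only part of what the source reports. "The series", "measured", "known", "first", "only" and "open" are said of these compounds alone.

Compounds measured so far in an assay on microsomes for inhibition of Amine oxidase [flavin-containing] A (Homo sapiens), read by fluorescence and spectrophotometry, with a stated time of 20 min; a lower number here means a stronger inhibitor, a higher number a weaker inhibitor:
Compound 1 `O=c1ccoc2ccc(OCCc3ccccc3)cc12` gives 3120 nM.
Compound 2 `O=c1ccoc2ccc(OCCCc3ccccc3)cc12` gives 1910 nM.
Compound 3 `O=c1ccoc2ccc(OCc3cccc(Cl)c3)cc12` gives 424 nM.

Compound 2 holds the second highest of the three numbers in this assay. Its nearest neighbour is compound 1, whose number is higher, and the step of a 1.6-fold lower number from compound 1 to compound 2 (0.21 log units; within the scatter) lies within the scatter. For the measured compounds named here, compound 3 stands furthest away with a number that is clearly lower, though no single-site step connects compound 3 to compound 2.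

The unmeasured compound 4 `O=c1ccoc2ccc(OCCc3ccc(Br)cc3)cc12` differs from compound 2 in one place: 4-bromophenyl in place of benzyl on a saturated chain carbon, two bonds along the chain from an oxygen on an aromatic ring. Going by the values given here, the only directly related step, a 1.6-fold lower number from compound 1 to compound 2 (0.21 log units; within the scatter), shows that lengthening the chain by one carbon changed little. The new compound keeps the shorter chain of compound 1 and adds a bromine to the ring. Among the compounds with values here, the pair compound 1 and compound 3 shows that a halogen on the ring, there with a still shorter chain, goes together with a markedly lower number, but no step is defined for that pair. Compound 4 is therefore expected to fall below compound 2, a step of a 2.1-fold lower number from compound 2 to compound 4 (0.33 log units; beyond the scatter), with an estimated 900 nM in this assay, within a range from 300 nM to 2700 nM.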

Compound 4, half-maximal inhibitory concentration: 480 nM
Compound 4: the middle estimate sits 1.9-fold (0.27 log units) above what was measured; the range from low to high includes it.
By their numbers in this assay, from the lowest: compounds 3 and 4 (each within the scatter of the next); then compounds 2 and 1 (each within the scatter of the next).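

In this assay, for the compounds shown here, bromo in place of hydrogen on an aromatic carbon gives the first single-place change here to reach beyond the scatter (a 6.5-fold lower number from compound 1 to compound 4 (0.81 log units; beyond the scatter)), whereas the one-carbon chain extension stayed within it (a 1.6-fold lower number from compound 1 to compound 2 (0.21 log units; within the scatter)). The change from benzyl to 4-bromophenyl on a saturated chain carbon, two bonds along the chain from an oxygen on an aromatic ring, also gives a step beyond the scatter (a 4.0-fold lower number from compound 2 to compound 4 (0.60 log units; beyond the scatter)), so at this place the ring substituent moved the number further than the chain length did. No measurement presented here accounts for this difference.

Going by these compounds, it remains open whether a methoxy or a nitrile in place of the bromo would give a similar number. Also open, on these data alone, is whether a bromo on the benzyl of compound 2 would lower its number in the same way.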